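Nitro to cyano in the cytotoxic amide series

This account rests on a few compounds, and the source may have more. Where it says the series, first, only, none or still open, it means among the compounds named here.

Compound 1 (`COc1cc(/C=C/C(=O)/C=C(O)/C=C/c2ccc(OC(C)(C)C(=O)Nc3ccc(C#N)c(C(F)(F)F)c3)c(OC)c2)ccc1O`): 48100 nM
Compound 2 (`COc1ccc(/C=C/C(=O)/C=C(O)/C=C/c2ccc(OC(C)(C)C(=O)Nc3ccc([N+](=O)[O-])c(C(F)(F)F)c3)c(OC)c2)cc1OC`): > 100000 nM

Both values come from a functional assay on PC-3 cells (Homo sapiens) for cytotoxicity, read by sulforhodamine B assay, with a stated time of 72 h; on this read-out higher numbers stand for weaker inhibition and lower numbers for stronger inhibition. Going by the values given here, compound 1 gives 48100 nM, the only true number in this small set. Compound 2 stands at > 100000 nM, which is a limit of the assay and not a number.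

The next compound to be read in this assay is compound 3 (`COc1ccc(/C=C/C(=O)/C=C(O)/C=C/c2ccc(OC(C)(C)C(=O)Nc3ccc(C#N)c(C(F)(F)F)c3)c(OC)c2)cc1OC`). It is reached from compound 2 by placing cyano in place of nitro on an aromatic carbon, ortho to a trifluoromethyl group and para to a large group: cyano in place of nitro on an aromatic carbon. Among the compounds with values here, no measured pair shows what this exchange does. The starting point has no number, and the size of any change remains loosely defined.

A modest step toward stronger inhibition is expected, and a second reading at the limit would not be a surprise. The expected change is an at least 1.4-fold lower number from compound 2 to compound 3 (0.15 log units; that floor lies within the scatter). This expectation is anchored on compound 1 at 48100 nM, the sole numerical reference available. Compound 3 is estimated at 70000 nM. The expected range for compound 3 runs from 30000 nM to 100000 nM.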

Compound 3, half-maximal inhibitory concentration: > 100000 nM
Compound 3: only a limit was reported; the forecaster's own chance of this, stated with the estimate: 45%; middle value at least 1.4-fold (0.15 log units) away from the limit.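

In this assay compound 3 gives > 100000 nM, which is a limit of the assay and not a number. Cyano in place of nitro on this aromatic carbon, ortho to a trifluoromethyl group, does not bring the compound to a measured value, and the size of the change cannot be read, because both ends of the step sit at the limit: the limit of > 100000 nM in this assay, at which 2 of the 3 values shown sit.

With cyano present on both sides, the series now has its first readable step, an at least 2.0-fold higher number from compound 1 to compound 3 (0.31 log units; beyond the scatter), for methyl in place of hydrogen on an oxygen on an aromatic ring, so in this pair cyano alone does not secure a measured value.

As far as these compounds go, the effect of that same hydrogen with nitro in place of cyano stays open, as does the true size of the step to compound 3, which has only a limit. Also open, from the compounds shown here alone, is whether an amine on the aromatic carbon now holding cyano, or an ethyl chain on the oxygen now holding methyl, would give a value inside the range of the assay.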